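A few compounds are considered here, and "the series" means these few. Any claim that something is new, unique, unknown or untested is made for them only; others in the source may bear on it.

Series notes. Three ureas on a shared core have so far been run in an ADME assay on HepG2 cells (Homo sapiens) for cytotoxicity, with a stated time of 72 h; on this read-out higher numbers stand for an effect only at larger amounts of compound and lower numbers for an effect already at smaller amounts. Compound 1 `Cc1cc(NC(=O)Nc2ccc([N+](=O)[O-])c(C(F)(F)F)c2)c2ccccc2n1` carries nitro and trifluoromethyl groups; in this assay compound 1 gives > 25000 nM, which is a limit of the assay and not a number. Compound 3 `Cc1cc(NC(=O)Nc2ccccc2C(F)(F)F)c2ccccc2n1` carries a trifluoromethyl group; in this assay compound 3 gives > 25000 nM, again a limit rather than a number. Compound 2 `COc1ccc(NC(=O)Nc2cc(C)nc3ccccc23)cc1`, carrying a methoxy group, is the reference for the next step; in this assay compound 2 gives > 25000 nM, once more a limit and not a number. Within the data shown here, compound 2 therefore stands where the other two stand, at the limit of > 25000 nM in this assay, at which 3 of the 3 values shown sit; no value in the set has been resolved into a number, and no step between measured compounds can be sized.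

Compound 4 `Cc1cc(NC(=O)Nc2ccc(O)cc2)c2ccccc2n1` has not yet been run. It differs from compound 2 by hydrogen in place of methyl on an oxygen on an aromatic ring, which one bond further out reads methoxy to hydroxy. With every measured compound sitting at the limit, there is nothing in the set pointing to a shift in either direction; the expected step that the limit leaves unreadable from compound 2 to compound 4 is none beyond the scatter. Compound 4 is accordingly expected to give about 30000 nM, within 15000 nM to 60000 nM, and most likely to be reported again only as a limit.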

Compound 4, half-maximal effective concentration: > 25000 nM
Compound 4: no number, only a limit (the forecaster's own chance of this, stated with the estimate: 75%); the middle value is on the limit's open side.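

Compound 4 gives > 25000 nM in this assay, a limit of the assay and not a number. Compound 2 is also held at a limit, so no step can be read between compound 2 and compound 4: the limit of > 25000 nM in this assay, at which 4 of the 4 values shown sit.

The compounds shown leave open what size the change from methoxy to hydroxy has in this assay.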